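This account rests on a few compounds, and the source may have more. Where it says the series, first, only, none or still open, it means among the compounds named here.

Of the compounds shown here, three of a shared core have been measured for agonist activity at the bile acid receptor. In an assay on isolated protein for agonist activity at Bile acid receptor (Homo sapiens), read by FRET (on this read-out lower numbers stand for an effect already at smaller amounts and higher numbers for an effect only at larger amounts of compound), compound 1 `CC(C)c1onc(-c2c(Cl)cccc2Cl)c1COc1ccc(N(C)C(=O)c2ccc(C(=O)O)cc2)c(C(F)(F)F)n1` gives 235 nM. Compound 2 `CC(C)c1onc(-c2c(Cl)cccc2Cl)c1COc1ccc(N(C)Cc2cccc(C(=O)O)c2)c(C(F)(F)F)n1` gives 12 nM, and the single one-place step recorded among these compounds is a 20-fold lower number from compound 1 to compound 2 (1.29 log units; beyond the scatter). Among the measured compounds shown here, compound 3 `CC(C)c1onc(-c2c(Cl)cccc2Cl)c1COc1ccc(N(C)Cc2ccc(C(=O)NS(C)(=O)=O)cc2)c(C(F)(F)F)n1` gives 40 nM in this assay; of the three numbers this is the second highest, with compound 2 giving a lower number and compound 1 a higher one, and no step between compound 3 and either of them is recorded beyond what the two values show.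

Compound 4 `CC(C)c1onc(-c2c(Cl)cccc2Cl)c1COc1ccc(N(C)Cc2ccc(OCC(=O)O)cc2)c(C(F)(F)F)n1` is not yet measured. It differs from compound 3 by carboxymethoxy in place of (methylsulfonyl)carbamoyl on an aromatic carbon. For the measured compounds named here, the only recorded step concerns a different part of the molecule, the group on the ring nitrogen, so it does not bear directly on this change; what remains is that compound 2 and compound 3, which both carry a benzyl bearing one hydrogen-bond donor group, give numbers within a narrow span. Compound 4 keeps that arrangement, so a step in this assay of modest size, expected a 1.6-fold lower number from compound 3 to compound 4 (0.20 log units; within the scatter), toward a somewhat lower number seems most likely, though a result within the scatter would not surprise. For compound 4 the estimate in this assay is 25 nM, expected to lie between 8 nM and 80 nM.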

Compound 4, half-maximal effective concentration: 35 nM
Compound 4: the middle estimate sits 1.4-fold (0.15 log units) below what was measured; measured number inside the range.
By their numbers in this assay, from the lowest: compound 2; then compounds 4 and 3 (each within the scatter of the next); then compound 1.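

Placing carboxymethoxy on this aromatic carbon, para to a large group, in place of (methylsulfonyl)carbamoyl gives a 1.1-fold lower number from compound 3 to compound 4 (0.06 log units; within the scatter), so this read-out does not separate the two groups here, even though the entering group has fewer heavy atoms and carries no sulfur or nitrogen. The other two comparisons are beyond the scatter: 4-(carboxymethoxy)phenyl in place of 3-carboxyphenyl gives a 2.9-fold higher number from compound 2 to compound 4 (0.46 log units; beyond the scatter), though that swap alters both the chain and the place on the ring, while 4-(carboxymethoxy)benzyl in place of (4-carboxyphenyl)carbonyl gives a 6.7-fold lower number from compound 1 to compound 4 (0.83 log units; beyond the scatter), a second case, after compound 2, of a benzyl compound with a lower number than carbonyl-linked compound 1. Nothing available here explains why these groups give these numbers.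

As far as these compounds go, a 3-(carboxymethoxy)benzyl group would help separate the effect of the chain from that of its place on the ring, and that comparison remains open. From the compounds shown here alone, it is also open whether a tetrazole, a primary amide or a longer chain ending in a carboxylic acid would fit on this same aromatic carbon.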